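A few compounds are considered here, and "the series" means these few. Any claim that something is new, unique, unknown or untested is made for them only; others in the source may bear on it.

Measured so far in a functional assay on GTL 16 cells for antiproliferative activity against GTL 16 cell line (Homo sapiens), read by CCK-8 assay, with a stated time of 72 h; a higher number here means a weaker inhibitor, a lower number a stronger inhibitor:
compound 1 `Cc1ccc(C(=O)Nc2cccc(-c3oc4cc(-c5ccc(F)cc5)ccc4c(=O)c3O)c2)cc1`: 12900 nM
compound 2 `Cc1ccccc1C(=O)Nc1cccc(-c2oc3cc(-c4ccc(F)cc4)ccc3c(=O)c2O)c1`: 24800 nM
compound 3 `Cc1cccc(C(=O)Nc2cccc(-c3oc4cc(-c5ccc(F)cc5)ccc4c(=O)c3O)c2)c1`: 10900 nM

Compound 2 gives the highest of the three numbers in this assay; the step of a 1.9-fold higher number from compound 1 to compound 2 (0.28 log units; within the scatter) lies within the scatter, and the step of a 2.3-fold lower number from compound 2 to compound 3 (0.36 log units; beyond the scatter) is only modest. Compound 4 `COc1ccc(C(=O)Nc2cccc(-c3oc4cc(-c5ccc(F)cc5)ccc4c(=O)c3O)c2)c(F)c1` differs from compound 2 by 2-fluoro-4-methoxyphenyl in place of 2-methylphenyl on a carbonyl carbon. Within the data shown here, no measured step involves a methoxy or a fluorine on the amide aryl group; the steps of a 1.9-fold higher number from compound 1 to compound 2 (0.28 log units; within the scatter), a 1.2-fold lower number from compound 1 to compound 3 (0.07 log units; within the scatter) and a 2.3-fold lower number from compound 2 to compound 3 (0.36 log units; beyond the scatter) all move a single methyl and stay small. A small step is therefore expected, a lower number being somewhat more likely since compound 2 gives 24800 nM, the top of the set. Compound 4 is expected to give 15000 nM, within 5000 nM to 45000 nM. The expected step is a 1.7-fold lower number from compound 2 to compound 4 (0.22 log units; within the scatter).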

Compound 4, half-maximal inhibitory concentration: 15300 nM
For compound 4 the middle estimate is 1.0-fold (0.01 log units) below the measured one; low and high end bracket the measured number.
By their numbers in this assay, from the lowest: compounds 3, 1, 4 and 2 (each within the scatter of the next, the first and the last beyond it).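

In this assay, 2-fluoro-4-methoxyphenyl on the carbonyl carbon brings the first oxygen and fluorine to this position, and the steps stay within the scatter: a 1.6-fold lower number from compound 2 to compound 4 (0.21 log units; within the scatter) and a 1.4-fold higher number from compound 3 to compound 4 (0.15 log units; within the scatter) and a 1.2-fold higher number from compound 1 to compound 4 (0.07 log units; within the scatter). This position therefore accepts a group with a hydrogen-bond acceptor without a step beyond the scatter in these four compounds. No available evidence bears on the reason for these small steps.

Open, on these data alone, is whether an amine or a carboxylic acid on this aryl group would move the number beyond the scatter. Also open, as far as these compounds go, is what the fluorine and the methoxy each contribute alone.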